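The source may hold more compounds than are shown below. What is called first, only, known or untested is meant among the compounds shown, and "the series" means these compounds.

In a functional assay on OVCAR-8 cells (Homo sapiens) for inhibition, read by sulforhodamine B assay, with a stated time of 48 h (on this read-out higher numbers stand for lower toxicity in this test and lower numbers for higher toxicity in this test), the three measured compounds share the core of compound 1 `COc1cc(-c2nn(-c3cccc(NC(=O)Nc4cc(C(F)(F)F)cc(C(F)(F)F)c4)c3)cc2-c2ccncc2)ccc1Cl` and all stop at the edge of the assay. For compound 1 only a limit was recorded, > 50000 nM. Compound 2 `COc1cc(-c2nn(-c3cccc(NC(=O)c4cccc(C(F)(F)F)c4)c3)cc2-c2ccncc2)ccc1Cl`, the amide of this set, likewise gave only a limit in this assay, > 50000 nM. Compound 3 `O=C(Nc1cccc(-n2cc(-c3ccncc3)c(-c3ccc(Cl)c(O)c3)n2)c1)Nc1ccc(Cl)c(Cl)c1` also reached only a limit in this assay, > 32500 nM. So compound 2 stands where every other value stands, at a limit rather than a number, with two of the three values sitting at the limit of > 50000 nM in this assay, at which 2 of the 3 values shown sit, and one at the limit of > 32500 nM in this assay, at which 1 of the 3 values shown sits.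

Compound 4 `COc1cc(-c2nn(-c3cccc(NC(=O)Nc4cccc(C(F)(F)F)c4)c3)cc2-c2ccncc2)ccc1Cl` differs from compound 2 in one place: (3-(trifluoromethyl)phenyl)amino in place of 3-(trifluoromethyl)phenyl on a carbonyl carbon. Among the compounds with values here, no measured step of this kind is available, and the only comparison on hand is that the ureas compound 1 and compound 3 and the amide compound 2 all sit at limits. The step from compound 2 to compound 4 in this assay is therefore expected to be none beyond the scatter, a step that the limit leaves unreadable from compound 2 to compound 4. Compound 4 is estimated at 60000 nM in this assay, within 20000 nM to 200000 nM, most likely again as a limit.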

Compound 4, concentration lethal to 50% of the cells: > 50000 nM
Compound 4: a limit, no number; the forecaster's own chance of this, stated with the estimate: 80%; the middle value lies beyond the limit too.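

Compound 4 gave only a limit in this assay, > 50000 nM, and neither the step from compound 2 nor the step from compound 1 can be read. The compounds shown leave open whether the urea and the amide differ at all in this assay, and what any of these compounds' actual values are.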